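Working notes: fluoro to methyl on compound 3

This account rests on a few compounds, and the source may have more. Where it says the series, first, only, none or still open, it means among the compounds named here.

Values measured in an ADME assay on HPLF cells (Homo sapiens) for cytotoxicity, with a stated time of 24 h; on this read-out higher numbers stand for lower toxicity in this test and lower numbers for higher toxicity in this test:

compound 1 `CN(C)c1ccc(/C=C2\CCC/C(=C\c3ccccc3[N+](=O)[O-])C2=O)cc1`: > 400000 nM (a limit of the assay, not a number)
compound 2 `COc1cc(/C=C2\CCC/C(=C\c3ccccc3[N+](=O)[O-])C2=O)cc(OC)c1OC`: 79000 nM
compound 3 `O=C1/C(=C/c2ccc(F)cc2)CCC/C1=C\c1cccc([N+](=O)[O-])c1`: 36000 nM

Only two of the three entries in this assay are numbers. Of these, compound 3 at 36000 nM is the lower, and compound 2 at 79000 nM stands higher, a gap beyond the usual scatter. The entry for compound 1 remains a limit and is not placed on the same scale.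

The next compound to be tested is compound 4 `Cc1ccc(/C=C2\CCC/C(=C\c3cccc([N+](=O)[O-])c3)C2=O)cc1`. It has methyl in place of fluoro on an aromatic carbon, para to a large group (methyl in place of fluoro on an aromatic carbon). Among the measured compounds shown here, no two measured compounds differ in one place only, so the series gives no direct measure of this change. Any expectation therefore rests on compound 3 at 36000 nM and on the small size of the structural change. No step beyond the scatter is expected in this assay, and no firm direction can be assigned. The expected step, a 1.1-fold higher number from compound 3 to compound 4 (0.05 log units; within the scatter), is an estimate and is correspondingly small. The estimated value for compound 4 is 40000 nM. The expected range for compound 4 runs from 16000 nM to 100000 nM.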

Compound 4, half-maximal cytotoxic concentration in the HPLF assay: > 400000 nM
Compound 4 was reported as a limit (the forecaster's own chance of this, stated with the estimate: 5%); middle value at least 10-fold (1.00 log units) away from the limit.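

Among the compounds shown here, the exchange of 4-fluorophenyl for 4-methylphenyl is the only one-place comparison so far, and in the HPLF assay it gives an at least 11-fold higher number from compound 3 to compound 4 (1.04 log units; beyond the scatter). For the compounds shown here, this shows that a single heavy atom on an aromatic carbon, para to a large group, can separate two otherwise identical compounds in this test, which the earlier compounds, differing in more than one place, could not show. In a physicochemical assay for lipophilicity (on this read-out lower numbers stand for lower lipophilicity and higher numbers for higher lipophilicity), the same exchange gives a number 0.28 log units higher from compound 3 to compound 4 (within the scatter), so the pair is separated clearly on only one of the two read-outs. In the physicochemical assay compound 3 gives 5.07 and compound 4 gives 5.35 (the two lie within the scatter).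

In the HPLF assay compound 3 gives 36000 nM as a number. In the HPLF assay compound 4 gives > 400000 nM as a limit of the assay and not a number, so the full size of the step stays unknown: the limit of > 400000 nM in the HPLF assay, at which 2 of the 4 values shown sit.

The two groups alone do not tell whether the step follows from the loss of fluoro or the arrival of methyl, and a chloro, methoxy or amine group at this place, or a bare hydrogen, would help to separate the two readings. As far as these compounds go, whether the exchange has the same outcome on the core of compound 1 or compound 2 also stays open.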